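The source may report more compounds than this note shows. Statements on the series, on what has been measured and on what is new or still open speak of the compounds shown alone.

Among the measured compounds shown here, compound 2 `O=C(Nc1cccc(-c2oc3cc(-c4ccc(F)cc4)ccc3c(=O)c2O)c1)c1cc(F)cc(F)c1` gives the lower of the two numbers so far in a functional assay on HepG2 cells (Homo sapiens) for antiproliferative activity, read by CCK-8 assay, with a stated time of 72 h (a lower number here means a stronger inhibitor, a higher number a weaker inhibitor), at 4960 nM; the nearest compound 1 `O=C(Nc1cccc(-c2oc3cc(-c4ccc(F)cc4)ccc3c(=O)c2O)c1)c1ccccc1F` gives 10100 nM, and the single step that joins the pair, a 2.0-fold lower number from compound 1 to compound 2 (0.31 log units; beyond the scatter), counts as modest. Compound 3 `O=C(Nc1cccc(-c2oc3cc(-c4ccc(F)cc4)ccc3c(=O)c2O)c1)c1ccc([N+](=O)[O-])cc1` has not yet been measured. It differs from compound 2 by 4-nitrophenyl in place of 3,5-difluorophenyl on a carbonyl carbon. For the measured compounds named here, the only step in hand changed the same aryl group on the carbonyl carbon and moved this assay by a modest amount; no measured step involves a nitro group, so neither direction is supported over the other. The expected step from compound 2 to compound 3 is therefore small, a 1.2-fold higher number from compound 2 to compound 3 (0.08 log units; within the scatter), probably within the scatter, with a wide range to allow for either direction. Compound 3 is expected to give 6000 nM in this assay, within 2000 nM to 20000 nM.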

Compound 3, half-maximal inhibitory concentration: 1860 nM
Estimate against measurement, compound 3: 3.2-fold (0.51 log units) above, outside the stated range (below it).
By their numbers in this assay, from the lowest: compound 3; then compound 2; then compound 1.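

In this assay, the aryl group on the carbonyl carbon now spans a wider range than the fluorinated pair alone showed. 4-Nitrophenyl in place of 3,5-difluorophenyl gives a 2.7-fold lower number from compound 2 to compound 3 (0.43 log units; beyond the scatter), and 4-nitrophenyl in place of 2-fluorophenyl gives a 5.4-fold lower number from compound 1 to compound 3 (0.73 log units; beyond the scatter), so compound 3 holds the lowest number of the three, with both steps beyond the scatter. No supporting measurement bears on why this change lowers the number.

On these data alone, it remains open whether a nitrile, a trifluoromethyl, an amine or a carboxylic acid in place of the nitro group on this phenyl ring would match 4-nitrophenyl. As far as these compounds go, it is also open whether a non-aromatic group, such as a longer alkyl chain, would be accepted on this carbonyl carbon.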